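Series notes: moving the chloro on the oxindole part

The compounds below may be only part of what the source reports. "The series", "measured", "known", "first", "only" and "open" are said of these compounds alone.

Of the compounds shown here, three have been measured in a functional assay on cells (Cancer cell lines, Homo sapiens) for cytotoxicity, with a stated time of 48 h; a higher number here means a weaker inhibitor of growth, a lower number a stronger inhibitor of growth. Compound 1 `COc1cc2c(/C=C3/C(=O)Nc4ccc(O)cc43)c(Cl)n(Cc3cc(OC)c(OC)c(OC)c3)c2cc1C` gives 2290 nM. Compound 2 `COc1cc2c(/C=C3/C(=O)Nc4ccc(Cl)cc43)c(Cl)n(Cc3cc(OC)c(OC)c(OC)c3)c2cc1C` gives 2190 nM, and compound 3 `O=C1/C(=C/c2c(Cl)[nH]c3ccccc23)c2ccccc2N1Cc1ccccc1` gives 4170 nM. Compound 1 thus sits at the second highest of the three numbers, with compound 2 nearest and compound 3 furthest away; both of those gaps fall within the scatter, so no order among the three can be stated.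

Compound 4 `COc1cc2c(/C=C3/C(=O)Nc4cccc(Cl)c43)c(Cl)n(Cc3cc(OC)c(OC)c(OC)c3)c2cc1C` is not yet measured. The change from compound 1 is a group of 12 heavy atoms (9 carbon, 1 nitrogen, 1 oxygen, 1 chlorine; one five-membered non-aromatic ring with 1 hetero atom, one six-membered aromatic ring of carbon only) in place of a group of 12 heavy atoms (9 carbon, 1 nitrogen, 2 oxygen; one five-membered non-aromatic ring with 1 hetero atom, one six-membered aromatic ring of carbon only), on an aromatic carbon. Going by the values given here, the one measured step that bears on it is a 1.0-fold lower number from compound 1 to compound 2 (0.02 log units; within the scatter), which also exchanges hydroxy for chloro on the same part of the molecule and produced nothing beyond the scatter. On that basis no step beyond the scatter is expected here either, in either direction.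

For compound 4 the expected value in this assay is 2300 nM, with a range from 1100 nM to 4800 nM. This estimate corresponds to an expected step of a 1.0-fold higher number from compound 1 to compound 4 (0.00 log units; within the scatter).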

Compound 4, concentration for 50% growth inhibition: 2880 nM
For compound 4 the middle estimate is 1.3-fold (0.10 log units) below the measured one, and the stated range covers the measured number.
By their numbers in this assay, from the lowest: compounds 2, 1, 4 and 3 (each within the scatter of the next).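

In this assay, moving the chloro group to a different aromatic carbon within the changing group gives a 1.3-fold higher number from compound 2 to compound 4 (0.12 log units; within the scatter), so the position of the chloro group, and not only its exchange for hydroxy, has now been tested without a step beyond the scatter. Removing the hydroxy and placing the chloro group elsewhere in a single change gives a 1.3-fold higher number from compound 1 to compound 4 (0.10 log units; within the scatter), which shows that going from 2 hydrogen-bond donors to 1 in this group, together with the new chloro position, also stays within the scatter. Nothing available on these compounds offers an explanation for this flat result.

Only hydroxy and chloro are shown on this ring, so it remains open whether an amine or a carboxylic acid here would produce a step beyond the scatter. Methoxy or a longer chain at these positions also remains open.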